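A Larger Saturated Ring on the Amide Carbonyl

This account rests on a few compounds, and the source may have more. Where it says the series, first, only, none or still open, it means among the compounds named here.

Of the compounds shown here, three sharing one core have been tested in an assay on LtK cells with ATP-sensitive inward rectifier potassium channel 11 (Homo sapiens) as the target; a higher number here means that more compound is needed for the effect, a lower number that less compound is needed. Compound 1 `CCC(C)C(=O)Nc1c(C(O)(C(F)(F)F)C(F)(F)F)ccc2ccccc12` gives 177000 nM. Compound 2 `C/C=C/C(=O)Nc1c(C(O)(C(F)(F)F)C(F)(F)F)ccc2ccccc12` gives 72 nM, and compound 3 `O=C(Nc1c(C(O)(C(F)(F)F)C(F)(F)F)ccc2ccccc12)C1CC1` gives 751 nM. Compound 3 stands second highest of the three numbers. All three measured steps concern the group on the carbonyl carbon: a 2500-fold lower number from compound 1 to compound 2 (3.39 log units; beyond the scatter), a 240-fold lower number from compound 1 to compound 3 (2.37 log units; beyond the scatter) and a 10-fold higher number from compound 2 to compound 3 (1.02 log units; beyond the scatter). The saturated, branched sec-butyl group gave the highest number by a wide margin, the unsaturated prop-1-en-1-yl group the lowest, and the small cyclopropyl ring sat in between.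

Compound 4 `O=C(CC1CCCC1)Nc1c(C(O)(C(F)(F)F)C(F)(F)F)ccc2ccccc12` is not yet measured. It differs from compound 3 in one place: cyclopentylmethyl in place of cyclopropyl on a carbonyl carbon. For the measured compounds named here, the steps that bear on this change are a 240-fold lower number from compound 1 to compound 3 (2.37 log units; beyond the scatter) and a 2500-fold lower number from compound 1 to compound 2 (3.39 log units; beyond the scatter), which show that a saturated, non-ring group on this carbonyl carbon fared far worse than either the small ring or the unsaturated chain. Cyclopentylmethyl is saturated and clearly larger than cyclopropyl, so a step toward a higher number is expected, estimated as a 40-fold higher number from compound 3 to compound 4 (1.60 log units; beyond the scatter). Compound 4 is therefore expected to give about 30000 nM, within a range of 4000 nM to 200000 nM.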

Compound 4, half-maximal effective concentration: 81 nM
Beside the measured number, compound 4's estimate is 370-fold (2.57 log units) above it; measured number outside the range, below it.
By their numbers in this assay, from the lowest: compounds 2 and 4 (each within the scatter of the next); then compound 3; then compound 1.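

Saturation alone does not set a high number at this carbonyl carbon: cyclopentylmethyl is saturated, yet it gives a 9.3-fold lower number from compound 3 to compound 4 (0.97 log units; beyond the scatter) in place of cyclopropyl and a 2200-fold lower number from compound 1 to compound 4 (3.34 log units; beyond the scatter) in place of sec-butyl. Nor is an unsaturated chain needed for a low number, since the replacement of prop-1-en-1-yl by cyclopentylmethyl gives a 1.1-fold higher number from compound 2 to compound 4 (0.05 log units; within the scatter), which leaves the two compounds indistinguishable. With the larger cyclopentylmethyl group giving a lower number than cyclopropyl and the saturated sec-butyl group remaining far out on the high side, neither group size nor saturation sorts these four compounds, and no supporting measurement is available to explain the difference.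

The compounds shown leave open whether the five-membered ring or the single carbon linking it to the carbonyl matters more, a question that cyclopentyl attached directly to the carbonyl carbon would address. They also leave open whether a straight butyl chain would behave like the branched sec-butyl group or like the ring-bearing cyclopentylmethyl group.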